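The source may report more compounds than this note shows. Statements on the series, on what has been measured and on what is new or still open speak of the compounds shown alone.

Compound 3 `O=C(C1=NC(c2c[nH]c3ccccc23)CN1)c1c[nH]c2cc(Br)ccc12` was tested in an ADME assay on SK-MEL-2 cells (Homo sapiens) for cytotoxicity; on this read-out higher numbers stand for an effect only at larger amounts of compound and lower numbers for an effect already at smaller amounts. There compound 3 gives > 30 ug/mL, which is a limit of the assay rather than a number; it sits at the limit of > 30 ug/mL in this assay, at which 1 of the 3 values shown sits. Two companions give actual numbers in this assay: compound 1 `O=C1NC[C@@H](c2c[nH]c3ccccc23)N=C1c1c[nH]c2ccccc12` gives 13.7 ug/mL, and compound 2 `O=C(C1=NC(c2c[nH]c3cc(Br)ccc23)CN1)c1c[nH]c2ccccc12` gives 5.04 ug/mL. Compound 4 `O=C(C1=NC(c2c[nH]c3cc(Br)ccc23)CN1)c1c[nH]c2cc(Br)ccc12` is the not yet measured neighbour of compound 3, and the change between them is bromo in place of hydrogen on an aromatic carbon. Among the compounds with values here, no measured step tells how such a change shifts this assay, so the step from compound 3 to compound 4 is expected to be small, an at least 1.2-fold lower number from compound 3 to compound 4 (0.07 log units; that floor lies within the scatter), within the usual scatter. Compound 4 is expected to come out near 25 ug/mL, with a likely range from 7 ug/mL to 60 ug/mL, and with a fair chance of again returning only a limit.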

Compound 4, concentration for half-maximal effect: 4.82 ug/mL
Compound 4: the middle estimate sits 5.2-fold (0.71 log units) above what was measured; the measured number lies below the stated range.
By their numbers in this assay, from the lowest: compounds 4 and 2 (each within the scatter of the next); then compound 1. At a limit, above all of these: compound 3.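

In this assay compound 3 stands only at a limit, not at a number: the limit of > 30 ug/mL in this assay, at which 1 of the 4 values shown sits.

Even against that limit, bromo in place of hydrogen at this position gives an at least 6.2-fold lower number from compound 3 to compound 4 (0.79 log units; beyond the scatter), so this position can clearly move the read-out. Within the data shown here, the other bromo, the one compound 3 already carries, gives only a 1.0-fold lower number from compound 2 to compound 4 (0.02 log units; within the scatter), so the lower number here goes with one particular bromo, not with bromine as such.

From the compounds shown here alone, whether chloro, methoxy or an amine at this position would shift the number the same way stays open.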